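The source may report more compounds than this note shows. Statements on the series, on what has been measured and on what is new or still open speak of the compounds shown alone.

Going by the values given here, in a functional assay on SMMC-7721 cells (Homo sapiens) for antiproliferative activity, read by MTT assay, with a stated time of 72 h (on this read-out lower numbers stand for stronger inhibition and higher numbers for weaker inhibition), compound 2 `Cc1nn(C)c(Oc2ccc(Cl)cc2)c1/C=N\OCc1c(Cl)c(-c2ccc(Cl)cc2)nn1C` gives 6820 nM, the lowest of the two numbers so far; compound 1 `Cc1nn(C)c(Oc2ccc(Cl)cc2)c1/C=N\OCc1c(Cl)c(-c2ccc(F)cc2)nn1C` gives 7970 nM, and the step of a 1.2-fold lower number from compound 1 to compound 2 (0.07 log units; within the scatter) stays within the scatter. Compound 3 `Cc1nn(C)c(Oc2ccc(OC(F)(F)F)cc2)c1/C=N\OCc1c(Cl)c(-c2ccc(Cl)cc2)nn1C` differs from compound 2 by trifluoromethoxy in place of chloro on an aromatic carbon. Among the compounds with values here, no measured step exchanges chloro for trifluoromethoxy; the only step seen, the exchange of fluoro for chloro elsewhere in the shared core, was within the scatter. The step of a 1.0-fold lower number from compound 2 to compound 3 (0.02 log units; within the scatter) is therefore expected to stay within the scatter. For compound 3 the estimate is 6500 nM, likely between 2500 nM and 16000 nM.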

Compound 3, half-maximal inhibitory concentration: 8670 nM
Beside the measured number, compound 3's estimate is 1.3-fold (0.13 log units) below it; the range from low to high includes it.
By their numbers in this assay, from the lowest: compounds 2, 1 and 3 (each within the scatter of the next).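

Exchanging chloro for trifluoromethoxy, which brings five heavy atoms in place of one and adds one hydrogen-bond acceptor, gives a 1.3-fold higher number from compound 2 to compound 3 (0.10 log units; within the scatter) in this assay. At this position, on an aromatic carbon para to a large group, the exchange therefore leaves the number within the scatter, as the earlier step elsewhere in the shared core did. No available evidence bears on the reason for this result. From the compounds shown here alone, whether an amine or a carboxylic acid at this position would move the number beyond the scatter remains open.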